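From methylcarbamoyl to hydroxy on a shared core

The compounds below may be only part of what the source reports. "The series", "measured", "known", "first", "only" and "open" are said of these compounds alone.

Values so far in a physicochemical assay for lipophilicity, at pH 7.4; a lower number here means a more polar compound, a higher number a more lipophilic compound
- compound 1 `O=C(Nc1ccc2[nH]nnc2c1)[C@H]1CCCN1C(=O)C1(c2cccc(Cl)c2)CCCC1` gives 5.2
- compound 2 `CNC(=O)c1ccc(NC(=O)[C@H]2CCCN2C(=O)C2(c3cccc(Cl)c3)CCCC2)cc1` gives 5.3

Within the data shown here, compound 2 (5.3) cannot be told apart from compound 1, the only other measured compound, as the gap between them lies within the scatter. The next compound is compound 3 `O=C(Nc1ccc(O)cc1)[C@H]1CCCN1C(=O)C1(c2cccc(Cl)c2)CCCC1` which keeps the shared core and changes one group: hydroxy in place of methylcarbamoyl on an aromatic carbon. In words, hydroxy takes the place of methylcarbamoyl on an aromatic carbon, para to a large group.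

Among the measured compounds shown here, only one measured step bears on this, and only loosely: a number 0.10 log units higher from compound 1 to compound 2 (within the scatter). It swapped a different pair of groups, and it stayed within the scatter. For the measured compounds named here, a single step is thin evidence, and no measured compound carries hydroxy, so the data offer no firm direction. A shift beyond the scatter in this assay is therefore not expected. The expected step is small and reads a number 0.10 log units higher from compound 2 to compound 3 (within the scatter). Compound 3 is estimated at 5.4 with an expected range from 5 to 5.8.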

Compound 3, distribution coefficient: 5.5
Compound 3: middle estimate off by 0.10 log units, on the low side; the measured number falls inside the stated range.
By their numbers in this assay, from the lowest: compounds 1, 2 and 3 (each within the scatter of the next).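

With a number 0.20 log units higher from compound 2 to compound 3 (within the scatter) at this aromatic carbon, this assay cannot separate methylcarbamoyl from hydroxy, even though the group that leaves is the larger of the two and both carry the same counts of hydrogen-bond donors and acceptors. The wider exchange on the amide-type nitrogen gives the same reading: with a number 0.30 log units higher from compound 1 to compound 3 (within the scatter) as well, all three compounds now lie within the scatter of one another, so none of these changes to that part of the molecule moves the number measurably. Nothing measured here accounts for this lack of separation.

As far as these compounds go, what would happen with an amine, a carboxylic acid or a longer chain such as ethylcarbamoyl on the same aromatic carbon remains open, so the present result cannot be taken as a rule for every group placed there. Also open, from the compounds shown here alone, is whether a methoxy group, which has no hydroxy hydrogen, would stay as close to compound 3 in this assay as methylcarbamoyl does, and whether the rest of the shared core would tolerate changes as readily.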